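This account rests on a few compounds, and the source may have more. Where it says the series, first, only, none or still open, it means among the compounds named here.

Measured in an ADME assay on microsomes from liver (Mus musculus) for metabolic stability, read by LC-MS, with a stated time of 10 min; a lower number here means that less of the compound is left, a higher number that more of the compound is left:
- compound 1 `CN1CCN(c2cccc3c2C[C@H](CN(C)[C@H]2CCCc4cccnc42)NC3)CC1`: 17%
- compound 2 `CN(C[C@H]1Cc2c(cccc2N2C[C@@H]3C[C@H]2CN3)CN1)[C@H]1CCCc2cccnc21`: 36.3%

Of these two numbers, compound 1 has the lower, at 17%. The nearest compound lies beyond the scatter, with the step of a number 19.3 percentage points higher from compound 1 to compound 2 (beyond the scatter).

The unmeasured compound 3 `CN1CCN(c2cccc3c2C[C@H](CN(C)[C@H]2CCCc4cccnc42)N(C)C3)CC1` keeps the groups of compound 1 except for one change: methyl in place of hydrogen on an amine nitrogen in a ring. That is, methyl in place of hydrogen on an amine nitrogen in a ring.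

Among the compounds with values here, only one measured step exists, and it is modest. That step, a number 19.3 percentage points higher from compound 1 to compound 2 (beyond the scatter), exchanges a group on an aromatic carbon, not on this amine nitrogen, so it offers no direct measure of the present change. Within the data shown here, no measured pair tests methyl in place of hydrogen at this place. The expectation therefore stays anchored on compound 1 at 17%, with a wide range and no firm direction.

The expected result is a number 1 percentage points lower from compound 1 to compound 3 (within the scatter), a step not expected to exceed the scatter. For compound 3 the estimated value is 16%, with an expected range of 6% to 32%.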

Compound 3, percent of the compound remaining: 41.7%
Compound 3: the middle estimate sits 25.7 percentage points below what was measured; the whole stated range lies below it.
By their numbers in this assay, from the lowest: compound 1; then compounds 2 and 3 (each within the scatter of the next).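

Working notes on the series: in this assay the amine nitrogen in the ring, next to the ring atom that bears a large group, proves to be a place where a very small change registers, since methyl in place of hydrogen gives a number 24.7 percentage points higher from compound 1 to compound 3 (beyond the scatter) and so adds no ring and no net charge. Within the data shown here, the only earlier reading, a number 19.3 percentage points higher from compound 1 to compound 2 (beyond the scatter), came from exchanging a group on an aromatic carbon, so the series now shows a step beyond the scatter at a second place on the core of compound 1, and one reached with a far smaller group than that exchange. No supporting measurement is available that accounts for the higher number at this nitrogen.

From the compounds shown here alone, whether the effect is particular to methyl remains open, as a longer chain such as ethyl, or an acetyl group, on the same nitrogen would be needed to tell. Also open, going by these compounds, is whether this methyl and the group of compound 2 on the aromatic carbon would add up when carried together on the shared core.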